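Compound 2 to compound 4: a swapped aryl group

The source may hold more compounds than are shown below. What is called first, only, known or untested is meant among the compounds shown, and "the series" means these compounds.

In a functional assay on RT-112 cells (Homo sapiens) for antiproliferative activity, read by MTT assay, with a stated time of 72 h (a higher number here means a weaker inhibitor of growth, a lower number a stronger inhibitor of growth), compound 1 (`COc1cc(Nc2ncnc3c(NC(=O)Nc4cccc(Oc5ccccc5)c4)cccc23)cc(OC)c1`) gives 14000 nM on the shared core. Compound 2 (`COc1cc(Nc2ncnc3c(NC(=O)Nc4cccc(Cl)c4Cl)cccc23)cc(OC)c1`) gives 63.2 nM and holds the lowest of the two numbers, beyond the scatter from compound 1. For compound 3 (`COc1cc(Nc2ncnc3c(NC(=O)Nc4ccc(C(F)(F)F)cc4[N+](=O)[O-])cccc23)cc(OC)c1`) the result is only a limit, > 20000 nM as reported. Compound 4 (`COc1cc(Nc2ncnc3c(NC(=O)Nc4ccc5c(c4)OCCO5)cccc23)cc(OC)c1`) is not yet measured and carries 2,3-dihydro-1,4-benzodioxin-6-yl in place of 2,3-dichlorophenyl on an amide-type nitrogen. Within the data shown here, no measured step isolates this change. Since compound 2 sits at 63.2 nM at the low end, a rise in this assay beyond the scatter is expected. The estimated step of a 24-fold higher number from compound 2 to compound 4 (1.38 log units; beyond the scatter) is upward. For compound 4 the estimated value is 1500 nM with an expected range from 150 nM to 15000 nM in this read-out.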

Compound 4, concentration for 50% growth inhibition: 2750 nM
Estimate against measurement, compound 4: 1.8-fold (0.26 log units) below, and the stated range covers the measured number.
By their numbers in this assay, from the lowest: compound 2; then compound 4; then compound 1. At a limit, above all of these: compound 3.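

In this assay, the change from 2,3-dichlorophenyl to 2,3-dihydro-1,4-benzodioxin-6-yl on an amide-type nitrogen gives a 44-fold higher number from compound 2 to compound 4 (1.64 log units; beyond the scatter) and is the only single-place step shown. The aryl group at this position therefore carries a large part of the growth inhibition seen for compound 2, and the step is clearly beyond the scatter. Nothing measured here gives a cause for this step.

Whether the rise follows from losing the chlorine atoms or from gaining the non-aromatic ring remains unresolved. On these data alone, how a pyridinyl group or an aminomethyl-substituted phenyl group would behave at this position is also open.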